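This account rests on a few compounds, and the source may have more. Where it says the series, first, only, none or still open, it means among the compounds named here.

Measured so far in a functional assay on MCF7 cells (Homo sapiens) for antiproliferative activity, read by MTT assay, with a stated time of 72 h; on this read-out lower numbers stand for stronger inhibition and higher numbers for weaker inhibition:
- compound 1 `COc1cc2c(Nc3ccc(C#N)cc3)ncnc2cc1OCCCN(C)Cc1ccccc1`: > 100000 nM (a limit)
- compound 2 `COc1cc2c(Nc3ccc(C#N)cc3)ncnc2cc1OCCCN1CCC(C)CC1`: 43100 nM
- compound 3 `COc1cc2c(Nc3ccc(C#N)cc3)ncnc2cc1OCCCN1CCCCC1CCO`: > 100000 nM (a limit)

Compound 3 reads > 100000 nM, which is a limit and not a number. The series is dominated by the limit of > 100000 nM in this assay, at which 2 of the 3 values shown sit. Only compound 2 gives a true number.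

The next compound is compound 4 `CCN1CCN(CCCOc2cc3ncnc(Nc4ccc(C#N)cc4)c3cc2OC)CC1`. It carries 4-ethylpiperazin-1-yl in place of 2-(2-hydroxyethyl)piperidin-1-yl on a saturated chain carbon, three bonds along the chain from an oxygen on an aromatic ring.

Two measured steps at this same place bear on the change: an at least 2.3-fold lower number from compound 1 to compound 2 (0.36 log units; beyond the scatter) on bringing in 4-methylpiperidin-1-yl, and an at least 2.3-fold higher number from compound 2 to compound 3 (0.36 log units; beyond the scatter) on bringing in 2-(2-hydroxyethyl)piperidin-1-yl. Both are at least modest, but each is only a bound, since each has a limit at one end.

Compound 4 gives up the group that came with the higher number, so a modest step to a lower number is expected in this assay, towards compound 2 at 43100 nM. A result at the limit remains quite possible. The expected change is an at least 1.6-fold lower number from compound 3 to compound 4 (0.22 log units; that floor lies within the scatter).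

For compound 4 the estimate is 60000 nM, with an expected range of 25000 nM to 150000 nM.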

Compound 4, half-maximal inhibitory concentration: 29900 nM
Beside the measured number, compound 4's estimate is 2.0-fold (0.30 log units) above it; the measured number falls inside the stated range.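

In this assay, 4-ethylpiperazin-1-yl on a saturated chain carbon, three bonds along the chain from an oxygen on an aromatic ring, gives an at least 3.3-fold lower number from compound 3 to compound 4 (0.52 log units; beyond the scatter), and also an at least 3.3-fold lower number from compound 1 to compound 4 (0.52 log units; beyond the scatter). Set against the only other true number, the change gives a 1.4-fold lower number from compound 2 to compound 4 (0.16 log units; within the scatter), so 4-ethylpiperazin-1-yl and 4-methylpiperidin-1-yl cannot be told apart in this assay, even though the first has a second hetero atom in the six-membered non-aromatic ring. Compound 3 also carries a six-membered non-aromatic ring, so the presence of such a ring does not by itself separate the compounds shown, and the steps from compounds at the limit remain bounds only: the limit of > 100000 nM in this assay, at which 2 of the 4 values shown sit.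

On these data alone, how far compound 1 and compound 3 lie past their limits remains open, and with it the true size of the steps that start from them. Also open, as far as these compounds go, is whether morpholin-4-yl, 4-methylpiperazin-1-yl or a longer chain to the same ring would move the number beyond the scatter around compound 2 and compound 4.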